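The compounds below may be only part of what the source reports. "The series", "measured", "known", "first", "only" and "open" are said of these compounds alone.

Measured in a functional assay on Bel-7402 cells (Homo sapiens) for inhibition, read by MTT assay (on this read-out higher numbers stand for weaker inhibition and lower numbers for stronger inhibition), so far:

Compound 1 `C=C1C(=O)[C@@]23C(=O)OC[C@]4([C@@H](OC(C)=O)CCC(C)(C)[C@H]4C=O)[C@@H]2CC[C@H]1[C@H]3OC(=O)c1ccc([N+](=O)[O-])cc1` gives 1740 nM
Compound 2 `C=C1C(=O)[C@@]23C(=O)OC[C@]4([C@@H](OC(C)=O)CCC(C)(C)[C@H]4C=O)[C@@H]2CC[C@H]1[C@H]3OC(=O)c1ccc(C)cc1` gives 2090 nM
Compound 3 `C=C1C(=O)[C@@]23C(=O)OC[C@]4([C@@H](OC(C)=O)CCC(C)(C)[C@H]4C=O)[C@@H]2CC[C@H]1[C@H]3OC(=O)c1ccccc1` gives 3050 nM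

On these numbers compound 1 is not separated from the other two. The steps of a 1.2-fold higher number from compound 1 to compound 2 (0.08 log units; within the scatter) and a 1.8-fold higher number from compound 1 to compound 3 (0.24 log units; within the scatter) and also a 1.5-fold higher number from compound 2 to compound 3 (0.16 log units; within the scatter) all lie within the scatter, so the three values can be given no order.

The unmeasured compound 4 `C=C1C(=O)[C@@]23C(=O)OC[C@]4([C@@H](OC(C)=O)CCC(C)(C)[C@H]4C=O)[C@@H]2CC[C@H]1[C@H]3OC(=O)c1ccccc1Cl` keeps the shared core. The difference 2-chlorophenyl in place of 4-nitrophenyl on a carbonyl carbon amounts to 2-chlorophenyl in place of 4-nitrophenyl on a carbonyl carbon. The measured steps bear on this only in part. Within the data shown here, they exchange nitro, methyl and hydrogen on an aromatic carbon, while no measured compound carries chlorine or a 2-chlorophenyl group, so that part of the change is untested.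

Because a 1.8-fold higher number from compound 1 to compound 3 (0.24 log units; within the scatter) stays within the scatter, and it is the widest of the three, no step beyond the scatter is expected in this assay and no firm direction can be named. The estimate is therefore placed amid the measured values. For compound 4 the estimated value is 2300 nM with an expected range from 1100 nM to 4500 nM in this read-out. The estimate means a 1.3-fold higher number from compound 1 to compound 4 (0.12 log units; within the scatter) as the expected step.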

Compound 4, half-maximal inhibitory concentration: 1390 nM
Compound 4: the middle estimate sits 1.7-fold (0.22 log units) above what was measured, and the stated range covers the measured number.
By their numbers in this assay, from the lowest: compounds 4, 1, 2 and 3 (each within the scatter of the next, the first and the last beyond it).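

In this assay, among these compounds, the step of a 2.2-fold lower number from compound 3 to compound 4 (0.34 log units; beyond the scatter) is the first to pass beyond the scatter, though only modestly, and it comes with chloro in place of hydrogen on an aromatic carbon. The exchanges among nitro, methyl and hydrogen had not shown that a change on this aromatic ring could separate two compounds, but the separation here holds only against compound 3: a 1.3-fold lower number from compound 1 to compound 4 (0.10 log units; within the scatter) and a 1.5-fold lower number from compound 2 to compound 4 (0.18 log units; within the scatter) both stay within the scatter, so the 2-chlorophenyl group cannot be told apart from the 4-nitrophenyl or the 4-methylphenyl group on the carbonyl carbon. Nothing at hand explains the step, and no cause can be assigned to it.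

Going by these compounds, whether the step seen with chlorine carries over to fluorine or bromine, or to a methoxy group or an amine on the aromatic ring, remains open. On these data alone, it is also open how the number would respond if a saturated ring or a longer alkyl chain took the place of the aromatic ring on the carbonyl carbon.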